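This account rests on a few compounds, and the source may have more. Where it says the series, first, only, none or still open, it means among the compounds named here.

Of the compounds shown here, three sharing one core have been measured in an ADME assay on S9 fraction from liver (Rattus norvegicus) for metabolic stability, read by LC-MS, using NADPH, with a stated time of 30 min; a lower number here means that less of the compound is left, a higher number that more of the compound is left. Compound 1 `CCCCCCCCc1ccc(OCC(=O)Cn2cnnn2)cc1` gives 22%. Compound 2 `CCCCCCCCc1ccc(OCC(=O)Cn2nnnc2C)cc1` gives 32% in this assay, and compound 3 `CCCCCCCCc1ccc(OCC(=O)Cn2nnnc2-c2ccccc2)cc1` gives 36%. Compound 3 holds the highest of the three numbers, though only narrowly: the step of a number 4 percentage points higher from compound 2 to compound 3 (within the scatter) lies within the scatter, while the step of a number 14 percentage points higher from compound 1 to compound 3 (beyond the scatter) lies beyond it, and the step of a number 10 percentage points higher from compound 1 to compound 2 (within the scatter) lies within the scatter.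

Compound 4 `CCCCCCCCc1ccc(OCC(=O)Cn2nnnc2-c2cccc(Cl)c2)cc1` differs from compound 3 in one place: chloro in place of hydrogen on an aromatic carbon. Read one bond further out, the change is phenyl to 3-chlorophenyl. Within the data shown here, none of the measured steps makes the same kind of change; each of them exchanges hydrogen, methyl or phenyl on an aromatic carbon of the core, and the closest guide is the step of a number 4 percentage points higher from compound 2 to compound 3 (within the scatter), which stayed within the scatter. Compound 4 is therefore expected to show a step of a number 4 percentage points higher from compound 3 to compound 4 (within the scatter) in this assay, not beyond the scatter. Compound 4 is estimated at 40%, with a range from 25% to 58%.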

Compound 4, percent of the compound remaining: 41%
Compound 4: the middle estimate sits 1 percentage points below what was measured; low and high end bracket the measured number.
By their numbers in this assay, from the lowest: compounds 1, 2, 3 and 4 (each within the scatter of the next, the first and the last beyond it).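

In this assay, among these compounds, chloro in place of hydrogen is the first change here on the six-membered aromatic ring of carbon only, rather than on the aromatic carbon of the core that carries hydrogen, methyl or phenyl, and it gives a number 5 percentage points higher from compound 3 to compound 4 (within the scatter), so adding this chlorine to the phenyl of compound 3 produces no step that stands clear of the scatter. The exchange of methyl for 3-chlorophenyl likewise stays unresolved, with a number 9 percentage points higher from compound 2 to compound 4 (within the scatter), whereas the exchange of hydrogen for 3-chlorophenyl gives a number 19 percentage points higher from compound 1 to compound 4 (beyond the scatter), the largest step in the set. Nothing available bears on why these numbers fall as they do.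

On these data alone, whether a fluoro, a methoxy or a carboxylic acid in place of this chloro would move the number beyond the scatter from compound 3 remains open. So does the effect of a shorter chain in place of the octyl chain.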